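Chain Extension on the Aminomethyl Chalcone

This account rests on a few compounds, and the source may have more. Where it says the series, first, only, none or still open, it means among the compounds named here.

Compound 1 `CCN(C)Cc1c(OC)cc(OC)c(C(=O)/C=C/c2ccccc2Cl)c1O` holds the lowest number of the two measured in a functional assay on PC-3 cells (Homo sapiens) for antiproliferative activity, with a stated time of 72 h (a higher number here means a weaker inhibitor, a lower number a stronger inhibitor), giving 3 nM there. Compound 2 `COc1cc(OC)c2c(=O)cc(-c3ccccc3Cl)oc2c1CN1CCCCC1` gives 15500 nM in this assay, a gap from compound 1 far beyond the scatter. Compound 3 `COc1cc(OC)c(C(=O)/C=C/c2ccccc2Cl)c(O)c1CN(C)CCCN(C)C` keeps the core of compound 1 and differs from it by (dimethylamino)methyl in place of hydrogen on a saturated chain carbon, two bonds along the chain from an amine nitrogen. Among the compounds with values here, no measured pair isolates this change. A small step in this assay is expected, if any, toward a weaker inhibitor, hardly beyond the scatter. For compound 3 the estimate is 6 nM, with a range of 1.5 nM to 25 nM. The expected change is a 2.0-fold higher number from compound 1 to compound 3 (0.30 log units; within the scatter).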

Compound 3, half-maximal inhibitory concentration: 14500 nM
For compound 3 the middle estimate is 2400-fold (3.38 log units) below the measured one; measured number outside the range, above it.
By their numbers in this assay, from the lowest: compound 1; then compounds 3 and 2 (each within the scatter of the next).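

In this assay, within the data shown here, the one change from ethyl(methyl)amino to (3-(dimethylamino)propyl)(methyl)amino on the shared core gives a 4800-fold higher number from compound 1 to compound 3 (3.68 log units; beyond the scatter), a large step. This chain carbon, two bonds along the chain from an amine nitrogen, is therefore not a free position for added (dimethylamino)methyl in this series. No measurement at hand accounts for the loss.

The compounds shown do not tell whether the loss follows the terminal dimethylamino group or the added chain length alone. A plain propyl chain, or one ending in a hydroxyl, would separate the two.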